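Nitro for trifluoromethyl in the methylated compounds

A few compounds are considered here, and "the series" means these few. Any claim that something is new, unique, unknown or untested is made for them only; others in the source may bear on it.

Measured in a functional assay (aorta) for inhibition, with Rattus norvegicus as the target; a lower number here means a stronger inhibitor, a higher number a weaker inhibitor:
- compound 1 `FC(F)(F)c1cccc(N2CCN(c3ccc(-c4ncns4)nn3)CC2)c1`: 70 nM
- compound 2 `Cc1nsc(-c2ccc(N3CCN(c4cccc(C(F)(F)F)c4)CC3)nn2)n1`: 0.3 nM

Compound 2 has the lower number of the two. For the measured compounds named here, the only measured step is a 230-fold lower number from compound 1 to compound 2 (2.37 log units; beyond the scatter), for methyl in place of hydrogen on an aromatic carbon. Compound 3 `Cc1nsc(-c2ccc(N3CCN(c4cccc([N+](=O)[O-])c4)CC3)nn2)n1` keeps that methyl and has nitro in place of trifluoromethyl on an aromatic carbon, meta to a large group: nitro in place of trifluoromethyl on an aromatic carbon. Going by the values given here, no measured step covers this exchange, so its size is poorly constrained. A modest rise in this assay is expected, given as a 3.3-fold higher number from compound 2 to compound 3 (0.52 log units; beyond the scatter), though it may not exceed the scatter. Compound 3 is expected at 1 nM, with an estimated range of 0.2 nM to 6 nM.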

Compound 3, half-maximal inhibitory concentration: 3 nM
Compound 3: middle estimate off by 3.0-fold (0.48 log units), on the low side; measured number inside the range.
By their numbers in this assay, from the lowest: compound 2; then compound 3; then compound 1.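

In this assay, nitro in place of trifluoromethyl on this aromatic carbon, meta to a large group, gives a 10-fold higher number from compound 2 to compound 3 (1.00 log units; beyond the scatter). The earlier step showed only the effect of the methyl, whereas this one shows that the series also responds to the group at this second position, with compound 3 still reaching 3 nM. No available measurement explains the size of this step.

Going by these compounds, whether a nitrile or a chlorine atom here would fall nearer compound 2 or compound 3 remains open. Also open, on these data alone, is whether the methyl step keeps its size with nitro on the ring.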